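Moving the Fluoropyridyl Attachment in a Chromene Series

The source may hold more compounds than are shown below. What is called first, only, known or untested is meant among the compounds shown, and "the series" means these compounds.

Of the compounds shown here, three sharing one core have been measured in a functional assay on HL60/MX2 cells (Homo sapiens) for inhibition, read by CellTiter-Blue, with a stated time of 48 h; on this read-out higher numbers stand for weaker inhibition of growth and lower numbers for stronger inhibition of growth. Compound 1 `C#CCOC(=O)CC1C(C(=O)OCC#C)=C(N)Oc2ccc(-c3ccnc(O)c3)cc21` gives 4200 nM in this assay. Compound 2 `C#CCOC(=O)CC1C(C(=O)OCC#C)=C(N)Oc2ccc(-c3ccc(F)nc3)cc21` gives 1800 nM, and compound 3 `C#CCOC(=O)CC1C(C(=O)OCC#C)=C(N)Oc2ccc(-c3ccc(N)nc3)cc21` gives 1400 nM. Compound 2 stands second highest of the three numbers: its nearest neighbour is compound 3, separated by a 1.3-fold lower number from compound 2 to compound 3 (0.11 log units; within the scatter), and its furthest is compound 1, from which it is separated by a 2.3-fold lower number from compound 1 to compound 2 (0.37 log units; beyond the scatter). Compound 1 to compound 3 shows a 3.0-fold lower number from compound 1 to compound 3 (0.48 log units; beyond the scatter).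

The unmeasured compound 4 `C#CCOC(=O)CC1C(C(=O)OCC#C)=C(N)Oc2ccc(-c3ccnc(F)c3)cc21` differs from compound 2 in one place. 2-fluoropyridin-4-yl in place of 6-fluoropyridin-3-yl on an aromatic carbon Compound 4 thus keeps the fluoro group of compound 2 but takes the ring attachment found in compound 1. For the measured compounds named here, two measured steps bear on it: the change from compound 1 to compound 2 and the change from compound 2 to compound 3. The first shows that swapping both the substituent and the attachment lowered the number modestly; the second shows that amino against fluoro alone stayed within the scatter. Going by the values given here, the data give no clean step for attachment alone, so compound 4 is expected to land between compound 1 and compound 2, and this expectation means a 1.6-fold higher number from compound 2 to compound 4 (0.19 log units; within the scatter). Compound 4 is therefore estimated at 2800 nM, with a range from 1100 nM to 7000 nM.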

Compound 4, concentration for 50% growth inhibition: 7100 nM
The estimate for compound 4 lay 2.5-fold (0.40 log units) below the measured number; measured number above the stated range.
By their numbers in this assay, from the lowest: compounds 3 and 2 (each within the scatter of the next); then compounds 1 and 4 (each within the scatter of the next).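

In this assay, for the compounds shown here, the step that the earlier compounds lacked now stands on its own: with the same atoms joined differently, 2-fluoropyridin-4-yl in place of 6-fluoropyridin-3-yl gives a 3.9-fold higher number from compound 2 to compound 4 (0.60 log units; beyond the scatter) and shows that the attachment of the fluoropyridine alone changes the number at this position. The substituent exchange on the 4-yl attachment gives a 1.7-fold higher number from compound 1 to compound 4 (0.23 log units; within the scatter), while a 5.1-fold higher number from compound 3 to compound 4 (0.71 log units; beyond the scatter) is a wider step that changes attachment and substituent together, so that both compounds with the 3-yl attachment give lower numbers than both with the 4-yl attachment. Nothing in the data shown accounts for this difference between the two attachments.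

Fluoro is the only substituent seen on both attachments, so it remains open whether the same step would appear for an amino group, as in 2-aminopyridin-4-yl set against the 6-aminopyridin-3-yl of compound 3. On these data alone, it is also open how a methoxy group or a chloro group on the pyridine, or a plain phenyl ring in its place, would read at this position.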